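Hexyl for cyclohexyl on the amine of compound 2

The source may hold more compounds than are shown below. What is called first, only, known or untested is meant among the compounds shown, and "the series" means these compounds.

Compound 2 `Clc1ccccc1Cn1nnc2c(NC3CCCCC3)nc(-c3ccccc3)nc21` gives 34000000 nM in an assay on isolated protein for binding affinity to adenosine receptor A1 (Bos taurus); a higher number here means a weaker inhibitor, a lower number a stronger inhibitor. Among the three numbers, compound 3 `CCCNc1nc(-c2ccccc2)nc2c1nnn2Cc1ccccc1` gives 37000000 nM, within the scatter of compound 2, while compound 1 `Fc1ccccc1Cn1nnc2c(NC3CCCCC3)nc(-c3ccccc3)nc21` gives 1150000 nM; the only single-place step recorded is a 30-fold higher number from compound 1 to compound 2 (1.47 log units; beyond the scatter), chloro in place of fluoro on an aromatic carbon. Compound 4 `CCCCCCNc1nc(-c2ccccc2)nc2c1nnn2Cc1ccccc1Cl` differs from compound 2 by hexyl in place of cyclohexyl on a nitrogen on an aromatic ring. Among the compounds with values here, no measured pair changes only this amine substituent, and compound 3 differs from compound 2 in more than one place, so no step bears on the change. The expected step of a 1.1-fold lower number from compound 2 to compound 4 (0.05 log units; within the scatter) is therefore none beyond the scatter. Compound 4 is estimated at 30000000 nM, with a range of 8000000 nM to 120000000 nM.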

Compound 4, inhibition constant: 31000000 nM
Estimate against measurement, compound 4: 1.0-fold (0.01 log units) below; the measured number falls inside the stated range.
By their numbers in this assay, from the lowest: compound 1; then compounds 4, 2 and 3 (each within the scatter of the next).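

In this assay, within the data shown here, hexyl in place of cyclohexyl on the nitrogen gives a 1.1-fold lower number from compound 2 to compound 4 (0.04 log units; within the scatter), the first single-place step at this position. With chloro on the aromatic carbon, the amine substituent with a ring and the one without cannot be told apart here, whereas the earlier step recorded a change at the halogen only. No available data explain this result.

Open, going by these compounds, is whether hexyl and cyclohexyl also match with fluoro in place of chloro. Also open, on these data alone, is how octyl, or a chain ending in a carboxylic acid, would read on this nitrogen.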